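A longer chain and a changed piperidine end

The compounds below may be only part of what the source reports. "The series", "measured", "known", "first", "only" and "open" are said of these compounds alone.

Compound 1 `COc1ccc(-c2cc(=O)c3ccc(OCCCN4CCC(CCO)CC4)cc3o2)cc1` gives 22.8 nM
Compound 2 `COc1ccc(-c2cc(=O)c3ccc(OCCCCN4CCC(CCO)CC4)cc3o2)cc1` gives 23.2 nM

Both numbers come from a functional assay, read by spectrophotometry (on this read-out lower numbers stand for an effect already at smaller amounts and higher numbers for an effect only at larger amounts of compound), and lie within the scatter of each other. Compound 2 at 23.2 nM therefore cannot be ranked against compound 1. Compound 3 `COc1ccc(-c2cc(=O)c3ccc(OCCCCCCN4CCC(C)CC4)cc3o2)cc1` has not been measured. Its difference from compound 2 reads 2-(4-methylpiperidin-1-yl)ethyl in place of 4-(2-hydroxyethyl)piperidin-1-yl on a saturated chain carbon, four bonds along the chain from an oxygen on an aromatic ring and so touches both the chain and the piperidine end. Within the data shown here, the one measured step that bears on this is a 1.0-fold higher number from compound 1 to compound 2 (0.01 log units; within the scatter) and it concerns only chain length, with a size within the scatter. Among the measured compounds shown here, no measured step shows what the loss of the 4-(2-hydroxyethyl)piperidin-1-yl group does, so the uncertainty stays wide. The step expected in this assay is a 1.2-fold lower number from compound 2 to compound 3 (0.06 log units; within the scatter) and so none beyond the scatter. For compound 3 the estimate is 20 nM with an expected range from 6 nM to 70 nM in this measurement.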

Compound 3, half-maximal effective concentration: 32.6 nM
Estimate against measurement, compound 3: 1.6-fold (0.21 log units) below, and the stated range covers the measured number.
By their numbers in this assay, from the lowest: compounds 1, 2 and 3 (each within the scatter of the next).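

In this assay, 2-(4-methylpiperidin-1-yl)ethyl in place of 4-(2-hydroxyethyl)piperidin-1-yl gives a 1.4-fold higher number from compound 2 to compound 3 (0.15 log units; within the scatter), and the same difference read against the shorter chain gives a 1.4-fold higher number from compound 1 to compound 3 (0.16 log units; within the scatter). The group that leaves holds 1 hydrogen-bond donor and the group that enters holds 0, yet neither step goes beyond the scatter, so among these compounds the hydroxyl is not needed for a number in this range. Nothing measured here offers an explanation for this result.

On these data alone, compound 3 differs from compound 2 in both chain length and piperidine end, so the effect of each alone remains unknown. Also open, as far as these compounds go, is whether a carboxylic acid or a primary amine in place of the methyl on the piperidine, or a still longer chain, would move the number beyond the scatter.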